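The source may report more compounds than this note shows. Statements on the series, on what has been measured and on what is new or still open speak of the compounds shown alone.

Measured in a functional assay (trachea) with Cavia porcellus as the target; a lower number here means a stronger inhibitor, a higher number a weaker inhibitor:
- compound 1 `CCCCn1nc(-c2cccnc2)c2ccccc2c1=O`: 2290 nM
- compound 2 `CCOC(=O)CCCn1nc(-c2cccnc2)c2ccccc2c1=O`: 10000 nM
- compound 3 `O=c1c2ccccc2c(-c2cccnc2)nn1CCO`: 4570 nM

Compound 3 cannot be told apart from the simple butyl-bearing member of the set, as shown by a 2.0-fold higher number from compound 1 to compound 3 (0.30 log units; within the scatter). It is separated from the ethoxycarbonyl-bearing member by a 2.2-fold lower number from compound 2 to compound 3 (0.34 log units; beyond the scatter).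

Compound 4 `O=C(O)Cn1nc(-c2cccnc2)c2ccccc2c1=O` has not yet been measured. It differs from compound 3 by carboxy in place of hydroxymethyl on a saturated chain carbon bound to an aromatic nitrogen.

Among the compounds with values here, no measured step makes this exact change, so the evidence is indirect. The steps among the chain variants are small, and the largest is a 4.4-fold higher number from compound 1 to compound 2 (0.64 log units; beyond the scatter). Within the data shown here, compound 2, the only measured compound with a carbonyl in its chain, gives 10000 nM, so a small move towards a higher number seems more likely than a lower one, and it may stay within the scatter.

The estimated step is a 1.5-fold higher number from compound 3 to compound 4 (0.19 log units; within the scatter). Compound 4 is expected at 7000 nM, with an estimated range from 2500 nM to 20000 nM.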

Compound 4, half-maximal inhibitory concentration: > 100000 nM
Compound 4: only a limit was reported; the forecaster's own chance of this, stated with the estimate: 20%; middle value at least 14-fold (1.15 log units) from the limit.
By their numbers in this assay, from the lowest: compounds 1 and 3 (each within the scatter of the next); then compound 2. At a limit, above all of these: compound 4.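

In this assay compound 4 gives > 100000 nM, which is a limit of the assay and not a number. Carboxy in place of hydroxymethyl, on a saturated chain carbon bound to an aromatic nitrogen, gives an at least 21-fold higher number from compound 3 to compound 4 (1.34 log units; beyond the scatter), so this position, where the earlier chain changes produced only small steps, does not tolerate every group. The ethoxycarbonyl group of compound 2 gave no warning of this, with an at least 10-fold higher number from compound 2 to compound 4 (1.00 log units; beyond the scatter) and, against the butyl-bearing member, an at least 43-fold higher number from compound 1 to compound 4 (1.64 log units; beyond the scatter).

The compounds shown leave open whether this large step belongs to the carboxy group itself or to its place on the chain. A carboxylic acid on a longer chain, or a primary amide or an amine at this place, would help separate the two.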